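A few compounds are considered here, and "the series" means these few. Any claim that something is new, unique, unknown or untested is made for them only; others in the source may bear on it.

Compound 1 `O=C1O/C(=C\Cn2cc(-c3ccc(Br)cc3)nn2)C(OCc2ccccc2)=C1OCc1ccccc1` was examined in a functional assay on SW-620 cells (Homo sapiens) for antiproliferative activity, read by MTT assay, with a stated time of 72 h; on this read-out higher numbers stand for weaker inhibition and lower numbers for stronger inhibition. In this assay compound 1 gives > 100000 nM, which is a limit of the assay and not a number. Compound 2 `Cc1ccc(-c2cn(C[C@H](O)[C@H]3OC(=O)C(OCc4ccccc4)=C3OCc3ccccc3)nn2)cc1` shares the core of compound 1. In this assay compound 2 gives > 100000 nM, again a limit rather than a number. Compound 1 therefore stands at the limit of > 100000 nM in this assay, at which 2 of the 2 values shown sit, with no numerical value to rank it. Compound 3 `O=C1O/C(=C\Cn2cc(-c3cccc(O)c3)nn2)C(OCc2ccccc2)=C1OCc1ccccc1` differs from compound 1 by 3-hydroxyphenyl in place of 4-bromophenyl on an aromatic carbon. Within the data shown here, no step between measured compounds is available, so the account expects no shift beyond the scatter in this assay, in either direction. Compound 3 is accordingly expected to give 100000 nM, within 30000 nM to 300000 nM. The estimated step of a number no higher from compound 1 to compound 3 (the limit leaves the size open) is expected to be none beyond the scatter, with a limit the most likely outcome.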

Compound 3, half-maximal inhibitory concentration: 69800 nM
For compound 3 the middle estimate is 1.4-fold (0.16 log units) above the measured one; low and high end bracket the measured number.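

At this position, an aromatic carbon of a five-membered aromatic ring with 3 nitrogen, compound 1 gave only a limit. In this assay compound 3 gives a true number, 69800 nM. From the compounds shown here alone, putting 3-hydroxyphenyl in place of 4-bromophenyl gives an at least 1.4-fold lower number from compound 1 to compound 3 (0.15 log units; that floor lies within the scatter), so only the floor of this step is known and its full size stays open. The remaining values are limits, not numbers: the limit of > 100000 nM in this assay, at which 2 of the 3 values shown sit.

The compounds shown leave open whether the step follows the loss of the bromine, the entry of the hydroxyl or the different place of the substituent on the phenyl ring. They also leave open how an amine or a carboxylic acid on that phenyl ring would read in this assay.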